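The source may report more compounds than this note shows. Statements on the series, on what has been measured and on what is new or still open speak of the compounds shown alone.

Compound 3, `CCN(CC)S(=O)(=O)c1ccc(S(=O)(=O)N2CCC[C@@H](C(=O)N3CCC(COC)CC3)C2)cc1`, gives 50 nM in a functional assay on MIA PaCa-2 cells (Homo sapiens) for inhibition, read by MTT assay, with a stated time of 3 days (a lower number here means a stronger inhibitor, a higher number a weaker inhibitor), the lowest of the three numbers recorded; compound 2, `CCN(CC)S(=O)(=O)c1ccc(S(=O)(=O)N2CCC[C@@H](C(=O)N[C@@H]3CCOC3)C2)cc1`, gives 100 nM, and compound 1, `CCN(CC)S(=O)(=O)c1ccc(S(=O)(=O)N2CCC[C@@H](C(=O)N3CC[C@@H](OC)C3)C2)cc1`, gives 1070 nM. Compound 4 is `CCN(CC)S(=O)(=O)c1ccc(S(=O)(=O)N2CCC[C@@H](C(=O)NC3CCOCC3)C2)cc1`. The change from compound 3 is (oxan-4-yl)amino in place of 4-(methoxymethyl)piperidin-1-yl on a carbonyl carbon. Going by the values given here, two measured steps bear on it: a 2.0-fold lower number from compound 2 to compound 3 (0.30 log units; within the scatter), which swaps one amino-linked saturated ring for a ring-nitrogen amide and stays within the scatter, and a 21-fold lower number from compound 1 to compound 3 (1.33 log units; beyond the scatter), which is large but starts from a different ring. Compound 4 returns to an amino-linked six-membered ring, so a step of a 2.0-fold higher number from compound 3 to compound 4 (0.30 log units; within the scatter) is expected, back toward the number of compound 2. Compound 4 is estimated at 100 nM, with a range from 40 nM to 250 nM.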

Compound 4, half-maximal inhibitory concentration: 1350 nM
Estimate against measurement, compound 4: 14-fold (1.13 log units) below; measured number outside the range, above it.
By their numbers in this assay, from the lowest: compounds 3 and 2 (each within the scatter of the next); then compounds 1 and 4 (each within the scatter of the next).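

At this carbonyl carbon, an amino-linked saturated ring does not by itself preserve the low number: the change shows a 27-fold higher number from compound 3 to compound 4 (1.43 log units; beyond the scatter), and oxan-4-yl in place of oxolan-3-yl on the amide-type nitrogen alone gives a 14-fold higher number from compound 2 to compound 4 (1.13 log units; beyond the scatter). The remaining step, a 1.3-fold higher number from compound 1 to compound 4 (0.10 log units; within the scatter), leaves the (oxan-4-yl)amino and 3-methoxypyrrolidin-1-yl groups unseparated. No evidence on hand accounts for these differences. Going by these compounds, it remains open whether the sharp rise belongs to the oxan-4-yl ring itself, and what an open-chain 2-methoxyethylamino group on the same carbonyl carbon would give.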